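The source may report more compounds than this note shows. Statements on the series, on what has been measured and on what is new or still open speak of the compounds shown alone.

Compound 1, `COc1cc(N)c(Cl)cc1NC(=O)C1CCN(CC2CCCCC2)CC1`, gives 2.9 mg/kg in a functional assay on the whole organism for antagonist activity, with Mus musculus as the target; a lower number here means that less compound is needed, a higher number that more compound is needed for the effect. Compound 3, `COc1cc(N)c(Cl)cc1NC(=O)C1CCN(Cc2ccccc2)CC1`, gives 0.5 mg/kg in this assay. Compound 2, `COc1cc(N)c(Cl)cc1NC(=O)C1CCN(CC2CCCCCC2)CC1`, reaches only > 10 mg/kg in this assay, which is a limit of the assay and not a number.

Of the two numbers, compound 1 holds the higher; the nearest is compound 3, reached by a 5.8-fold lower number from compound 1 to compound 3 (0.76 log units; beyond the scatter). Compound 4, `COc1cc(N)c(Cl)cc1NC(=O)C1CCN(C/C=C/c2ccccc2)CC1`, is not yet measured and differs from compound 1 by 2-phenylethenyl in place of cyclohexyl on a saturated chain carbon bound to an amine nitrogen in a ring. Within the data shown here, two measured steps bear on it: a 5.8-fold lower number from compound 1 to compound 3 (0.76 log units; beyond the scatter), where an aromatic ring lowered the number, and an at least 3.4-fold higher number from compound 1 to compound 2 (0.53 log units; beyond the scatter), where a larger saturated ring pushed the value to the limit (the limit of > 10 mg/kg in this assay, at which 1 of the 3 values shown sits). The entering 2-phenylethenyl carries the aromatic ring of compound 3 yet brings more heavy atoms than cyclohexyl, as cycloheptyl did, so compound 4 is expected to show a 1.9-fold lower number from compound 1 to compound 4 (0.29 log units; within the scatter). Compound 4 is estimated at 1.5 mg/kg, between 0.4 mg/kg and 5 mg/kg.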

Compound 4, dose for half-maximal effect: > 10 mg/kg
Compound 4: only a limit was reported; the forecaster's own chance of this, stated with the estimate: 10%; middle value at least 6.6-fold (0.82 log units) away from the limit.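

Compound 4 shows that an aromatic ring at this position does not by itself lower the number: 2-phenylethenyl gives an at least 3.4-fold higher number from compound 1 to compound 4 (0.53 log units; beyond the scatter) and an at least 20-fold higher number from compound 3 to compound 4 (1.30 log units; beyond the scatter). Both steps rest on a limit of the assay and not on a number, and the step between compound 2 and compound 4 cannot be read. Cycloheptyl and 2-phenylethenyl, one saturated and one aromatic, both end at this limit: the limit of > 10 mg/kg in this assay, at which 2 of the 4 values shown sit.

The compounds shown leave open whether the double bond or the longer reach counts, which a saturated 2-phenylethyl group would separate. They also leave open whether a pyridyl ring could replace the phenyl of compound 3.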